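The source may hold more compounds than are shown below. What is called first, only, known or untested is meant among the compounds shown, and "the series" means these compounds.

Working notes on the series. Compound 1 `CC(=O)Nc1nc2ccc(-c3cnc(Cl)c(NS(=O)(=O)c4ccc(F)cc4)c3)cn2n1` in a functional assay on MCF7 cells (Homo sapiens) for antiproliferative activity, read by MTT assay, with a stated time of 48 h (a lower number here means a stronger inhibitor, a higher number a weaker inhibitor), gives 19800 nM; among the two numbers in hand this is the highest. Its nearest neighbour is compound 2 `CC(=O)Nc1nc2ccc(-c3cnc(Cl)c(NS(=O)(=O)c4ccc(C)cc4)c3)cn2n1`, which in this assay gives 3250 nM; the change from compound 1 to compound 2 is methyl in place of fluoro on an aromatic carbon of the sulfonamide aryl, giving a 6.1-fold lower number from compound 1 to compound 2 (0.78 log units; beyond the scatter).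

Compound 3 `COc1ncc(-c2ccc3nc(NC(C)=O)nn3c2)cc1NS(=O)(=O)c1ccc(F)cc1` differs from compound 1 elsewhere: methoxy in place of chloro on an aromatic carbon. Going by the values given here, the only measured step concerns the sulfonamide aryl, not the ring carrying the chloro, so no step bears directly on this change. The evidence for a direction is therefore absent, and the expectation for this assay is a step from compound 1 to compound 3 of a 1.3-fold lower number from compound 1 to compound 3 (0.12 log units; within the scatter), that is, none clearly beyond the scatter, with wide uncertainty in both directions because compound 1 sits at 19800 nM with no comparable exchange on its own ring to anchor the guess. The estimate for compound 3 is 15000 nM, with a range from 4000 nM to 60000 nM.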

Compound 3, half-maximal inhibitory concentration: 840 nM
The estimate for compound 3 lay 18-fold (1.25 log units) above the measured number; measured number below the stated range.
By their numbers in this assay, from the lowest: compound 3; then compound 2; then compound 1.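

In this assay, the place on the six-membered aromatic ring with 1 nitrogen, next to the ring nitrogen, turns out to be sensitive to what it carries: with methoxy entering where chloro leaves, the series shows a 24-fold lower number from compound 1 to compound 3 (1.37 log units; beyond the scatter), a large step. Going by these compounds alone, the only earlier step, a 6.1-fold lower number from compound 1 to compound 2 (0.78 log units; beyond the scatter), was modest and lay on the sulfonamide aryl, so the series now holds one change on each of two parts of compound 1, and the change on the ring carrying the chloro is the one graded large. Nothing in hand gives a cause for this step.

From the compounds shown here alone, whether the step belongs to methoxy itself or to any loss of chloro remains open: an amine, a methyl or an ethoxy at this place would tell these readings apart. Equally open, going by these compounds, is whether methoxy in place of chloro gives a step of like size on the sulfonamide aryl of compound 2, which carries methyl where compound 1 carries fluoro.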